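Tetrahydronaphthyl to Isopropylphenyl on a Glycoside Scaffold

A few compounds are considered here, and "the series" means these few. Any claim that something is new, unique, unknown or untested is made for them only; others in the source may bear on it.

Measured compounds:
- compound 1, `CO[C@H]1O[C@H](COc2cccc3c2CCCC3)[C@@H](O)[C@H](O)[C@H]1Oc1ccc(OC2CCCCC2)cc1`, "not determined" (no result reported)
- compound 2, `CO[C@H]1O[C@H](COc2ccc(-c3ccccc3)cc2)[C@@H](O)[C@H](O)[C@H]1Oc1ccccc1C(C)C`, 34000 nM

The series rests on a shared sugar core carrying two aryl ethers. Compound 1 has no number in a functional assay on MDA-MB-231 cells (Homo sapiens) for cytotoxicity, read by MTT assay, with a stated time of 48 h; on this read-out higher numbers stand for an effect only at larger amounts of compound and lower numbers for an effect already at smaller amounts; for it the record shows only that no result was reported. For the measured compounds named here, both aryl ether groups differ between compound 1 and compound 2; in this assay compound 2 gives 34000 nM, and that is the only measured value available.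

Compound 3, `CO[C@H]1O[C@H](COc2cccc(C(C)C)c2)[C@@H](O)[C@H](O)[C@H]1Oc1ccc(OC2CCCCC2)cc1`, keeps the cyclohexyloxyphenyl ether of compound 1 and changes the other aryl group: 3-isopropylphenyl in place of 1,2,3,4-tetrahydronaphthalen-5-yl on an oxygen on a saturated carbon. Going by the values given here, with compound 1 unmeasured, no step between measured compounds is known, and nothing links this change to a particular shift in this assay. The expected step from compound 1 to compound 3 is therefore judged as none beyond the scatter, in no particular direction, with compound 2 the only anchor for the level.

Compound 3 is estimated at 30000 nM in this assay, within a range of 8000 nM to 100000 nM.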

Compound 3, half-maximal effective concentration: 38000 nM
Beside the measured number, compound 3's estimate is 1.3-fold (0.10 log units) below it, and the stated range covers the measured number.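

For the compounds shown here, compound 1 has no single number in this assay, so the result for compound 3, 38000 nM, gives no step from compound 1 to compound 3. No evidence on the cause of any difference is available here. The compounds shown leave open what exchanging 1,2,3,4-tetrahydronaphthalen-5-yl for 3-isopropylphenyl does to the read-out on the shared core.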